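This account rests on a few compounds, and the source may have more. Where it says the series, first, only, none or still open, it means among the compounds named here.

Measured compounds: compound 1 `CC[C@@H]1C(=O)N(C)c2cnc(-n3ccc4cc(F)ccc43)nc2N1C1CCCC1` gives "not active" (no number reported) in a functional assay on HeLa cells (Homo sapiens) for antiproliferative activity, read by CCK-8 assay, with a stated time of 72 h; on this read-out lower numbers stand for stronger inhibition of growth and higher numbers for weaker inhibition of growth; compound 2 `CC[C@@H]1C(=O)N(C)c2cnc(-n3ccc4cc(C(=O)NCC(C)C)ccc43)nc2N1C1CCCC1` gives 3280 nM; compound 3 `CCCCNC(=O)c1ccc2c(ccn2-c2ncc3c(n2)N(C2CCCC2)[C@H](CC)C(=O)N3C)c1` gives 346 nM.

Compound 3 has the lowest number of the two reported, with compound 2 well above it and compound 1 carrying no number at all. Compound 4 `CC[C@@H]1C(=O)N(C)c2cnc(-n3ccc4cc(C(N)=O)ccc43)nc2N1C1CCCC1` is still to be measured in this assay; it differs from compound 3 by hydrogen in place of butyl on an amide-type nitrogen. Going by the values given here, the only step that bears on this, a 9.5-fold lower number from compound 2 to compound 3 (0.98 log units; beyond the scatter), shows that reshaping the chain on this amide nitrogen moves the number beyond the scatter. Among the compounds with values here, removing the chain entirely is a change no measured pair covers, so the direction is uncertain, though a move back toward compound 2 is expected. Compound 4 is expected to give 2500 nM, between 500 nM and 12000 nM. The expected step is a 7.2-fold higher number from compound 3 to compound 4 (0.86 log units; beyond the scatter).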

Compound 4, concentration for 50% growth inhibition: 674 nM
Compound 4: middle estimate off by 3.7-fold (0.57 log units), on the high side, within the range that was stated.
By their numbers in this assay, from the lowest: compounds 3 and 4 (each within the scatter of the next); then compound 2.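

In this assay, taking the butyl chain off this amide nitrogen gives a 1.9-fold higher number from compound 3 to compound 4 (0.29 log units; within the scatter) and stays within the scatter, so the plain carbamoyl group and butylcarbamoyl cannot be told apart here. Hydrogen in place of isobutyl gives a 4.9-fold lower number from compound 2 to compound 4 (0.69 log units; beyond the scatter) and lies beyond the scatter. A chain on this nitrogen is therefore not needed for a number in this range, and it is the isobutyl compound that stands apart.

No measurement here explains this difference between butyl and isobutyl. Going by these compounds, whether a longer chain, a cyclohexyl ring or a chain ending in an amine would track butyl or isobutyl at this nitrogen stays open.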